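The source may hold more compounds than are shown below. What is called first, only, known or untested is meant among the compounds shown, and "the series" means these compounds.

Values in a functional assay on OCI-Ly3 cells (Homo sapiens) for antiproliferative activity (a higher number here means that more compound is needed for the effect, a lower number that less compound is needed), are these:

Compound 1 `Cc1c(NC(=O)Nc2cnc(-n3nccn3)c(Cl)c2)cnc2ccccc12` gives 7170 nM
Compound 2 `O=C(Nc1cnc(-n2nccn2)c(Cl)c1)Nc1cnc2ccccc2c1C1CC1` gives 1580 nM
Compound 3 `COC(C)(C)c1c(NC(=O)Nc2cnc(-n3nccn3)c(Cl)c2)cnc2ccccc12` gives 4430 nM

Compound 3 lies in the upper pair of these three numbers. It cannot be separated from the methyl member (a 1.6-fold lower number from compound 1 to compound 3 (0.21 log units; within the scatter)) and sits clear of the cyclopropyl member (a 2.8-fold higher number from compound 2 to compound 3 (0.45 log units; beyond the scatter)). Compound 4 `CC(O)c1c(NC(=O)Nc2cnc(-n3nccn3)c(Cl)c2)cnc2ccccc12` carries 1-hydroxyethyl in place of 1-methoxy-1-methylethyl on an aromatic carbon. Among the measured compounds shown here, no measured step brings in this group, so the evidence is indirect. At the same place, the exchange of methyl for 1-methoxy-1-methylethyl stayed small (a 1.6-fold lower number from compound 1 to compound 3 (0.21 log units; within the scatter)), and the exchange of methyl for cyclopropyl, the largest seen, was modest (a 4.5-fold lower number from compound 1 to compound 2 (0.66 log units; beyond the scatter)). No step beyond the scatter is therefore expected in this assay, with only a slight lean towards a higher number. The estimated change is small (a 1.1-fold higher number from compound 3 to compound 4 (0.05 log units; within the scatter)). Compound 4 is expected at 5000 nM in a range of 1800 nM to 14000 nM by this estimate.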

Compound 4, half-maximal effective concentration: 730 nM
Compound 4: middle estimate off by 6.8-fold (0.84 log units), on the high side, outside the stated range (below it).
By their numbers in this assay, from the lowest: compound 4; then compound 2; then compounds 3 and 1 (each within the scatter of the next).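

At this place on the shared core, opposite the ring nitrogen, the choice of group matters more in this assay than compound 1, compound 2 and compound 3 had indicated: 1-hydroxyethyl gives the largest step seen here, a 9.8-fold lower number from compound 1 to compound 4 (0.99 log units; beyond the scatter), along with a 6.1-fold lower number from compound 3 to compound 4 (0.78 log units; beyond the scatter). Among the compounds shown here, it also goes past the cyclopropyl member, a 2.2-fold lower number from compound 2 to compound 4 (0.34 log units; beyond the scatter), so compound 4 is the one compound whose steps to all the others lie beyond the scatter, all towards a lower number. Nothing measured here accounts for this result.

The change from 1-methoxy-1-methylethyl alters the heavy-atom count and the hydrogen-bond donor count together, and the compounds shown cannot separate the two. They also leave open how a 1-methoxyethyl group, which keeps the same chain but has no hydrogen-bond donor, or a 1-aminoethyl group would compare.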